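Ring exchange on the thiocarbonyl carbon, compound 2 to 3

The source may hold more compounds than are shown below. What is called first, only, known or untested is meant among the compounds shown, and "the series" means these compounds.

Working notes on the series. Compound 1 `Cc1ccnc(/C(N)=N/NC(=S)N2CCOCC2)c1` and compound 2 `Cc1cccc(/C(N)=N/NC(=S)N2CCSCC2)n1` have been run in a functional assay on MCF7 cells (Homo sapiens) for cytotoxicity, read by MTT assay, with a stated time of 72 h, tested at 30 uM; on this read-out lower numbers stand for less inhibition of growth and higher numbers for more inhibition of growth at the one concentration tested. In this assay compound 1 gives 8.16%. In this assay compound 2 gives 38.6%, the higher of the two numbers by a margin beyond the scatter. The two structures differ in more than one place, so only the values themselves are noted. Compound 3 `Cc1cccc(/C(N)=N/NC(=S)N2CCCCC2)n1` is not yet measured; it carries piperidin-1-yl in place of thiomorpholin-4-yl on a thiocarbonyl carbon. Going by the values given here, no measured pair covers this exchange, so no step beyond the scatter is expected in this assay. The expected step is a number 3.6 percentage points lower from compound 2 to compound 3 (within the scatter). For compound 3 the estimate is 35%, within 15% to 55%.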

Compound 3, percent growth inhibition at one concentration: 43%
Compound 3: the middle estimate sits 8 percentage points below what was measured, and the stated range covers the measured number.
By their numbers in this assay, from the lowest: compound 1; then compounds 2 and 3 (each within the scatter of the next).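

In this assay, piperidin-1-yl in place of thiomorpholin-4-yl on a thiocarbonyl carbon gives a number 4.4 percentage points higher from compound 2 to compound 3 (within the scatter). As the first pair differing in one place, compound 2 and compound 3 show that this position takes either ring, with or without the ring sulfur, and the two cannot be told apart on this read-out.

Open, going by these compounds, is how a piperazin-1-yl ring or an open-chain dimethylamino group would read on the core of compound 2. Compound 1 differs from both in more than one place, so its value cannot be assigned to its morpholin-4-yl ring. No measurement at hand offers an explanation for the result.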